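This account rests on a few compounds, and the source may have more. Where it says the series, first, only, none or still open, it means among the compounds named here.

Measured so far in a functional assay (Nicotiana tabacum); a lower number here means a stronger inhibitor, a higher number a weaker inhibitor:
Compound 1 `CCCCCCNc1nc(SC)nc2ncccc12` gives 3330 nM
Compound 2 `CCCCCCCNc1nc(SC)nc2ncccc12` gives 4070 nM

On these numbers, compound 2 cannot be told apart from compound 1. Compound 3 `CCCCC(CC)CNc1nc(SC)nc2ncccc12` alters the chain of compound 2 (1-ethylpentyl in place of hexyl on a saturated chain carbon bound to a nitrogen on an aromatic ring), with 1-ethylpentyl in place of hexyl on a saturated chain carbon bound to a nitrogen on an aromatic ring. For the measured compounds named here, only one measured step bears on this change, and it also lies in that chain (a 1.2-fold higher number from compound 1 to compound 2 (0.09 log units; within the scatter)). It is a weak guide: no branched chain has been measured. No shift beyond the scatter is therefore expected in this assay, in either direction. The expected step is small (a 1.1-fold higher number from compound 2 to compound 3 (0.04 log units; within the scatter)). For compound 3 the estimated value is 4500 nM (expected range 1800 nM to 11000 nM).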

Compound 3, half-maximal inhibitory concentration: 15900 nM
The estimate for compound 3 lay 3.5-fold (0.55 log units) below the measured number; the measured number lies above the stated range.
By their numbers in this assay, from the lowest: compounds 1 and 2 (each within the scatter of the next); then compound 3.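

In this assay the chain on the shared core proves not to be indifferent to change: 1-ethylpentyl in place of hexyl gives a 3.9-fold higher number from compound 2 to compound 3 (0.59 log units; beyond the scatter), and ethyl in place of hydrogen on a saturated chain carbon bound to two saturated chain carbons gives a 4.8-fold higher number from compound 1 to compound 3 (0.68 log units; beyond the scatter). Compound 3 is thus a weaker inhibitor than both compound 1 and compound 2, whereas the straight-chain step a 1.2-fold higher number from compound 1 to compound 2 (0.09 log units; within the scatter) had shown no change that could be told from noise. Nothing given here accounts for this loss on branching.

Going by these compounds, with a single branched chain in hand, it remains open whether a smaller methyl branch would cost as much as the ethyl one. Also open, on these data alone, is how a longer straight chain or a cyclohexyl group would fare in this place.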